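Oxazole-linked lactone series: a propenyl variant in cytotoxicity

The source may report more compounds than this note shows. Statements on the series, on what has been measured and on what is new or still open speak of the compounds shown alone.

Measured compounds:
compound 1 `CC(=O)O[C@H]1C=CC(=O)O[C@@H]1c1nc(/C=C/c2ccccc2)oc1-c1ccccc1`, 24600 nM
compound 2 `CC(=O)O[C@H]1C=CC(=O)O[C@@H]1c1nc(-c2ccccc2)oc1-c1ccccc1`, 15700 nM
compound 3 `CC(=O)O[C@H]1C=CC(=O)O[C@@H]1[C@@H](O)[C@H](O)c1ccccc1`, > 40000 nM

In a functional assay on SMMC-7721 cells (Homo sapiens) for cytotoxicity, read by MTT assay, with a stated time of 48 h (on this read-out lower numbers stand for stronger inhibition and higher numbers for weaker inhibition), compound 2 gives 15700 nM, the lowest of the two numbers shown. Compound 1 sits nearest, the step of a 1.6-fold lower number from compound 1 to compound 2 (0.20 log units; within the scatter) being within the scatter, so no order between compound 1 and compound 2 is claimed. Compound 3 reaches only the limit (the limit of > 40000 nM in this assay, at which 1 of the 3 values shown sits), which is a limit of this assay and not a number.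

Compound 4 `C/C=C\c1nc([C@H]2OC(=O)C=C[C@@H]2OC(C)=O)c(-c2ccccc2)o1` is not yet measured. It differs from compound 2 by prop-1-en-1-yl in place of phenyl on an aromatic carbon. Among the measured compounds shown here, the only measured step that bears on this position is a 1.6-fold lower number from compound 1 to compound 2 (0.20 log units; within the scatter), where phenyl replaced 2-phenylethenyl and the number hardly moved. Here the ring leaves and a shorter prop-1-en-1-yl enters; the data give no step for such a change, so the expected step in this assay, a 1.6-fold higher number from compound 2 to compound 4 (0.20 log units; within the scatter), is set close to no change with wide uncertainty. Compound 4 is therefore estimated at 25000 nM, with a range from 10000 nM to 60000 nM.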

Compound 4, half-maximal inhibitory concentration: > 40000 nM
Compound 4: no number, only a limit (the forecaster's own chance of this, stated with the estimate: 30%); middle value at least 1.6-fold (0.20 log units) away from the limit.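

In this assay this position, on an aromatic carbon next to the ring nitrogen and next to the ring oxygen, now shows a step beyond the scatter: prop-1-en-1-yl in place of phenyl gives an actual loss (an at least 2.5-fold higher number from compound 2 to compound 4 (0.40 log units; beyond the scatter)), whereas the earlier swap of phenyl for 2-phenylethenyl had stayed within it. Against compound 1 the floor of the step lies within the scatter (an at least 1.6-fold higher number from compound 1 to compound 4 (0.21 log units; that floor lies within the scatter)), so no order between compound 1 and compound 4 is claimed. The entry for compound 4 is a limit and not a number: the limit of > 40000 nM in this assay, at which 2 of the 4 values shown sit.

Going by these compounds, how far compound 4 lies past that limit stays open, and with it the full size of both steps. On these data alone, whether a saturated propyl chain or an amine at this position would sit with compound 2 or with compound 4 also stays open.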